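Swapping a hydroxy for an amino on compound 1

The compounds below may be only part of what the source reports. "The series", "measured", "known", "first", "only" and "open" are said of these compounds alone.

Of the compounds shown here, three have been measured in a functional assay on MCF7 cells (Homo sapiens) for inhibition, read by MTT assay, with a stated time of 2 days; on this read-out higher numbers stand for weaker inhibition and lower numbers for stronger inhibition. Compound 1 `Oc1ccccc1/C=C/c1ccccc1O` gives 23 ug/mL, compound 2 `Nc1cccc(/C=C/c2ccccc2)c1` gives 14 ug/mL, and compound 3 `Oc1cccc(/C=C/c2cccc(O)c2)c1` gives 21 ug/mL. Compound 1 holds the highest of the three numbers, but its gaps to compound 3 and to compound 2 both lie within the usual scatter, so these three cannot be told apart on the data so far.

Compound 4 `Nc1ccccc1/C=C/c1ccccc1O` has not yet been measured. It differs from compound 1 in one place: amino in place of hydroxy on an aromatic carbon. For the measured compounds named here, no pair among the measured compounds differs in only one place, so no single-step comparison is available. Compound 2, which also carries an amino, gives 14 ug/mL, where compound 1 gives 23 ug/mL; yet those two structures differ in more than that one group, and their two numbers lie within the scatter of each other.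

On this footing compound 4 is expected to stay close, with an estimated step of a 1.3-fold lower number from compound 1 to compound 4 (0.11 log units; within the scatter) that is not larger than the scatter. The estimate for compound 4 in this assay is 18 ug/mL, with a range from 8 ug/mL to 40 ug/mL.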

Compound 4, half-maximal inhibitory concentration: 39 ug/mL
Compound 4: middle estimate off by 2.2-fold (0.34 log units), on the low side; measured number inside the range.
By their numbers in this assay, from the lowest: compounds 2, 3, 1 and 4 (each within the scatter of the next, the first and the last beyond it).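

For the compounds shown here, the exchange of hydroxy for amino on an aromatic carbon, ortho to a group of 9 heavy atoms, provides the first comparison in this assay between compounds that differ in one place, and it reads as a 1.7-fold higher number from compound 1 to compound 4 (0.23 log units; within the scatter). At this position, therefore, the amino group can stand in for the hydroxy without a change that can be distinguished from the scatter, so this hydroxy is not shown to be needed for the read-out to stay in the range of compound 1, although a single pair says nothing about other positions or other cores. No measurement shown here explains this result or bears on why the two groups read alike.

What the compounds shown leave open is whether a methoxy group, a fluorine or a carboxylic acid at this same position would also stay within the scatter of compound 1, or would produce a step beyond it. Going by these compounds, it also remains open what would happen if the remaining hydroxy of compound 4 were exchanged for an amino group as well.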